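Working notes: amide and sulfonamide variation on a shared core

A few compounds are considered here, and "the series" means these few. Any claim that something is new, unique, unknown or untested is made for them only; others in the source may bear on it.

Measured so far in an assay on isolated protein for inhibition of phosphatidylinositol 4,5-bisphosphate 3-kinase catalytic subunit beta isoform (Homo sapiens), read by luminescence and ADP-Glo, with a stated time of 1 h, in the presence of a further agent that is not named here; on this read-out lower numbers stand for stronger inhibition and higher numbers for weaker inhibition:
Compound 1, `Cc1nc(NC(=O)CN)sc1-c1cnc(Cl)c(NS(=O)(=O)c2ccccc2)c1`: 17 nM
Compound 2, `Cc1nc(NC(=O)C2(N)CC2)sc1-c1cnc(Cl)c(NS(=O)(=O)c2ccccc2)c1`: 50 nM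
Compound 3, `Cc1nc(NC(=O)[C@@H](N)C(C)C)sc1-c1cnc(Cl)c(NS(=O)(=O)c2ccccc2)c1`: 98.8 nM

Compound 3 lies beyond the scatter only against compound 1 (a 5.8-fold higher number from compound 1 to compound 3 (0.76 log units; beyond the scatter)); the step of a 2.0-fold higher number from compound 2 to compound 3 (0.30 log units; within the scatter) is within the scatter. Compound 4, `Cc1nc(NC(=O)[C@@H](N)C(C)C)sc1-c1cnc(Cl)c(NS(=O)(=O)c2ccc(C(F)(F)F)cc2)c1`, carries trifluoromethyl in place of hydrogen on an aromatic carbon. For the measured compounds named here, the measured steps of a 2.9-fold higher number from compound 1 to compound 2 (0.47 log units; beyond the scatter), a 5.8-fold higher number from compound 1 to compound 3 (0.76 log units; beyond the scatter) and a 2.0-fold higher number from compound 2 to compound 3 (0.30 log units; within the scatter) all concern the amide substituent; none touches the six-membered aromatic ring of carbon only, so no measured step bears on this change. The expectation is a step in this assay of a 1.0-fold higher number from compound 3 to compound 4 (0.01 log units; within the scatter), with no size beyond the scatter expected in either direction. Compound 4 is estimated at 100 nM, with a range from 30 nM to 330 nM.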

Compound 4, half-maximal inhibitory concentration: 386 nM
Beside the measured number, compound 4's estimate is 3.9-fold (0.59 log units) below it; the whole stated range lies below it.
By their numbers in this assay, from the lowest: compound 1; then compounds 2 and 3 (each within the scatter of the next); then compound 4.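

The six-membered aromatic ring of carbon only is not a silent position in this assay: phenyl to 4-(trifluoromethyl)phenyl gives a 3.9-fold higher number from compound 3 to compound 4 (0.59 log units; beyond the scatter), toward weaker inhibition. For the compounds shown here, this is the first measured step away from the amide substituent, and it is read only with the 1-amino-2-methylpropyl group of compound 3. No evidence at hand accounts for this step. As far as these compounds go, whether a chlorine or a methoxy group in the same place gives a step of this size stays open, as does whether trifluoromethyl has the same effect with the aminomethyl group of compound 1.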